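The compounds below may be only part of what the source reports. "The series", "measured", "known", "first", "only" and "open" are said of these compounds alone.

Three compounds sharing one core were tested in a functional assay on Caco-2 cells (Homo sapiens) for inhibition, read by MTT assay, with a stated time of 48 h; on this read-out higher numbers stand for weaker inhibition and lower numbers for stronger inhibition. Compound 1 `COc1cc(/C=N/Nc2nc(-c3ccc(F)c(F)c3)cs2)cc(Br)c1OC` gives 21200 nM in this assay, compound 2 `COc1cc(/C=N/Nc2nc(-c3ccc(F)c(F)c3)cs2)c(Br)c(Br)c1OC` gives 22800 nM, and compound 3 `Fc1ccc(/C=N/Nc2nc(-c3ccc(Br)cc3)cs2)cc1F` gives 43900 nM. For the measured compounds named here, the only measured step, a 1.1-fold higher number from compound 1 to compound 2 (0.03 log units; within the scatter), stays within the scatter. Compound 2 thus stands within the scatter of both compound 1 and compound 3. Compound 4 `COc1cc(/C=N/Nc2nc(-c3ccc(Br)cc3)cs2)c(Br)c(Br)c1OC` differs from compound 2 by 4-bromophenyl in place of 3,4-difluorophenyl on an aromatic carbon. Going by the values given here, no measured step makes this same exchange on this core, so the numbers for compound 2 and compound 3, which carry the two groups but also differ elsewhere, are the only guide, and they lie within the scatter of each other. The expected change in this assay is a 1.3-fold higher number from compound 2 to compound 4 (0.12 log units; within the scatter), nothing beyond the scatter. Compound 4 is therefore estimated to give 30000 nM, within a range of 12000 nM to 75000 nM.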

Compound 4, half-maximal inhibitory concentration: > 100000 nM
Compound 4 ended at the assay's limit (the forecaster's own chance of this, stated with the estimate: 10%); middle value at least 3.3-fold (0.52 log units) from the limit.
By their numbers in this assay, from the lowest: compounds 1, 2 and 3 (each within the scatter of the next, the first and the last beyond it). At a limit, above all of these: compound 4.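

This position of the shared core does not tolerate every aryl group equally: in this assay, 4-bromophenyl in place of 3,4-difluorophenyl gives an at least 4.3-fold higher number from compound 2 to compound 4 (0.64 log units; beyond the scatter), the first single-place step shown that lies beyond the scatter. The reading for compound 4 is a limit of the assay and not a number, so the full size of this step stays unknown: the limit of > 100000 nM in this assay, at which 1 of the 4 values shown sits.

Going by these compounds, whether the entering bromine or the departing fluorines matter more stays open. So does what a plain phenyl, a 4-fluorophenyl or a 4-aminophenyl group would do at this position.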